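The compounds below may be only part of what the source reports. "The series", "measured", "known", "first", "only" and "open" are said of these compounds alone.

Compound 1, `O=C(CCCc1cn(S(=O)(=O)c2ccccc2)c2ccccc12)NCCCn1ccnc1`: 13200 nM
Compound 2, `O=C(CCCc1cn(S(=O)(=O)c2ccsc2)c2ccccc12)NCCCn1ccnc1`: 13800 nM
Compound 3, `O=C(CCCc1cn(S(=O)(=O)c2cccnc2)c2ccccc12)NCCCn1ccnc1`: 26900 nM

In an assay on isolated protein for activation of Insulin-degrading enzyme (Homo sapiens), read by fluorescence, with stated times of 10 min and 20 min (on this read-out higher numbers stand for an effect only at larger amounts of compound and lower numbers for an effect already at smaller amounts), compound 1 gives 13200 nM. Compound 2 sits alongside it, as a 1.0-fold higher number from compound 1 to compound 2 (0.02 log units; within the scatter) shows, so the two cannot be told apart. Compound 3 stands further off: a 2.0-fold higher number from compound 1 to compound 3 (0.31 log units; beyond the scatter), while a 1.9-fold higher number from compound 2 to compound 3 (0.29 log units; within the scatter) is within the scatter. Compound 1 thus gives the lowest number of the three, separated only from compound 3.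

Compound 4, `O=C(CCCc1cn(S(=O)(=O)c2ccccc2)c2ccccc12)NCCCCn1ccnc1`, differs from compound 1 in one place: (1H-imidazol-1-yl)methyl in place of 1H-imidazol-1-yl on a saturated chain carbon, three bonds along the chain from an amide-type nitrogen. None of the three measured steps touches this part of the molecule; all of them change the ring on the sulfonyl sulfur, and even the largest of them, from compound 1 to compound 3, is modest. Within the data shown here, there is therefore no measured step that bears directly on the change to compound 4, and the expectation is for no step beyond the scatter, in either direction. Compound 4 is estimated at 13000 nM, with a range from 5000 nM to 35000 nM in this assay, which means an expected step of a 1.0-fold lower number from compound 1 to compound 4 (0.01 log units; within the scatter).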

Compound 4, half-maximal effective concentration: 8130 nM
Compound 4: the middle estimate sits 1.6-fold (0.20 log units) above what was measured, and the stated range covers the measured number.
By their numbers in this assay, from the lowest: compounds 4, 1, 2 and 3 (each within the scatter of the next, the first and the last beyond it).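

In this assay the step reads a 1.6-fold lower number from compound 1 to compound 4 (0.21 log units; within the scatter) and so compound 1 and compound 4 cannot be told apart. The earlier steps shown here all changed the ring on the sulfonyl sulfur, whereas this one shows that the imidazole-bearing chain can go from 3-(1H-imidazol-1-yl)propyl to 4-(1H-imidazol-1-yl)butyl with no step beyond the scatter. No evidence is at hand that bears on this result.

Going by these compounds, whether a still longer chain, a shorter chain, or a primary amine or carboxylic acid in place of the 1H-imidazol-1-yl group would shift the number beyond the scatter remains open. So does whether the pyridin-3-yl and thiophen-3-yl rings on the sulfonyl sulfur would give the same picture on the 4-(1H-imidazol-1-yl)butyl chain.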